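This account rests on a few compounds, and the source may have more. Where it says the series, first, only, none or still open, it means among the compounds named here.

Working notes on the series.

Two compounds share a cyanoguanidine core and carry a pyridine on one side; they have been measured in a functional assay on the whole organism (blood, strain Wistar-Okamoto) with Rattus norvegicus as the target, with a stated time of 5 days; a higher number here means that more compound is needed for the effect, a lower number that less compound is needed. Compound 1, `N#CN/C(=N\Cc1ccccc1)Nc1cccnc1`, gives 20 mg/kg in this assay. Compound 2, `CC(C)(C)C/N=C(\NC#N)Nc1ccncc1`, gives 5 mg/kg in this assay. Compound 2 stands at the lowest of the two numbers, and its nearest neighbour is compound 1 at a gap that lies beyond the scatter.

Compound 3, `N#CN/C(=N\Cc1ccccc1)Nc1ccncc1`, has not yet been measured in this assay. Against compound 2 the change is phenyl in place of tert-butyl on a saturated chain carbon bound to a double-bonded nitrogen. Going by the values given here, compound 1 carries phenyl at the same place and the core of compound 1 differs from that of compound 3 only in its pyridine, so the value of compound 1 is the closest guide for the expected effect of phenyl here, though no step between these two compounds is available.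

The step from compound 2 to compound 3 in this assay is expected to be a 2.4-fold higher number from compound 2 to compound 3 (0.38 log units; beyond the scatter), upward, close to the edge of the scatter. For compound 3 the estimate in this assay is 12 mg/kg, with a range from 5 mg/kg to 30 mg/kg.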

Compound 3, minimum effective dose: 5 mg/kg
Beside the measured number, compound 3's estimate is 2.4-fold (0.38 log units) above it; low and high end bracket the measured number.
By their numbers in this assay, from the lowest: compounds 2 and 3 (each within the scatter of the next); then compound 1.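

In this assay, phenyl in place of tert-butyl on a saturated chain carbon bound to a double-bonded nitrogen gives no change at the digits printed from compound 2 to compound 3 (within the scatter), so with pyridin-4-yl on the amine nitrogen this position accepts a six-membered aromatic ring as readily as a branched group with no ring. Going by these compounds alone, with phenyl held at that place, pyridin-4-yl in place of pyridin-3-yl on an amine nitrogen gives a 4.0-fold lower number from compound 1 to compound 3 (0.60 log units; beyond the scatter), which is the only single-place step in this set that lies beyond the scatter, and it places the one readable change at the pyridine rather than at the chain carbon. No other measurement accompanies these numbers that could account for either step.

The compounds shown leave open whether the pyridine step keeps its size with tert-butyl in place of phenyl on the chain carbon, as the two steps available both rest on compound 3. They also leave open whether the absence of change at the chain carbon extends to other groups there, such as a cyclohexyl ring, a longer chain or a carboxylic acid.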